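Swapping Methoxy for Chloro on the Pendant Phenyl Ring

The compounds below may be only part of what the source reports. "The series", "measured", "known", "first", "only" and "open" are said of these compounds alone.

Measured compounds in a functional assay on HL-60 cells (Homo sapiens) for antiproliferative activity, read by MTT assay, with a stated time of 72 h; a higher number here means a weaker inhibitor, a lower number a stronger inhibitor:
Compound 1 `COc1ccccc1-c1ncnn1-c1cc(OC)c(OC)c(OC)c1` gives a limit of the assay, > 10000 nM.
Compound 2 `COc1cc(-n2ncnc2-c2cccc(F)c2)cc(OC)c1OC` gives a limit of the assay, > 10000 nM.
Compound 3 `COc1ccc(-c2ncnn2-c2cc(OC)c(OC)c(OC)c2)cc1` gives 120 nM.

Among the measured compounds shown here, compound 3 is the only compound with a real number; the other two sit at the limit of > 10000 nM in this assay, at which 2 of the 3 values shown sit, so compound 3 is the reference point for anything new. Compound 4 `COc1cc(-n2ncnc2-c2ccc(Cl)cc2)cc(OC)c1OC` differs from compound 3 by chloro in place of methoxy on an aromatic carbon. The measured steps that touch this position are an at least 83-fold lower number from compound 1 to compound 3 (1.92 log units; beyond the scatter) and an at least 83-fold lower number from compound 2 to compound 3 (1.92 log units; beyond the scatter), both large, but each exchanges a whole substituted phenyl ring rather than a single group at the place where the chloro enters, so neither reads directly onto the change to compound 4. The direction and size of the step are therefore uncertain; a moderate weakening is expected, as a limit with no number cannot be excluded. Compound 4 is expected to give 500 nM, between 100 nM and 4000 nM, a step of a 4.2-fold higher number from compound 3 to compound 4 (0.62 log units; beyond the scatter).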

Compound 4, half-maximal inhibitory concentration: > 10000 nM
Compound 4: only a limit was reported; the forecaster's own chance of this, stated with the estimate: 20%; middle value at least 20-fold (1.30 log units) away from the limit.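

In this assay, among the compounds shown here, the earlier steps exchanged a whole substituted phenyl ring, whereas this change keeps the substituent in the same place, para to a large group, and replaces only methoxy with chloro, giving an at least 83-fold higher number from compound 3 to compound 4 (1.92 log units; beyond the scatter). So among the compounds shown, having a substituent in this place is not enough, since the identity of the group also matters here, and only the 4-methoxyphenyl of compound 3 gives a measurable number. The value of compound 4, > 10000 nM, is a limit of the assay, which places it with most of the series: the limit of > 10000 nM in this assay, at which 3 of the 4 values shown sit.

The steps joining compound 1, compound 2 and compound 4 link two limits and cannot be read. As far as these compounds go, whether ethoxy, hydroxy or an amine in this same place would keep a measurable value stays open.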